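Nucleoside series: the nitro and methyl groups relocated

A few compounds are considered here, and "the series" means these few. Any claim that something is new, unique, unknown or untested is made for them only; others in the source may bear on it.

The shared core carries a variable group on a saturated chain carbon bound to a nitrogen on an aromatic ring. Compound 1 `CCCCCNc1ncnc2c1ncn2[C@@H]1O[C@H](CO)[C@@H](O)[C@H]1O` gives 13500 nM in an assay on isolated protein for binding affinity to Equilibrative nucleoside transporter 1 (Homo sapiens); a higher number here means a weaker inhibitor, a lower number a stronger inhibitor. Compound 2 `OC[C@H]1O[C@@H](n2cnc3c(NCc4ccco4)ncnc32)[C@H](O)[C@@H]1O` gives 36300 nM in this assay, and the step of a 2.7-fold higher number from compound 1 to compound 2 (0.43 log units; beyond the scatter). Compound 3 `Cc1ccc([N+](=O)[O-])c(CNc2ncnc3c2ncn3[C@@H]2O[C@H](CO)[C@@H](O)[C@H]2O)c1` gives 1290 nM in this assay, the lowest of the three numbers; it is set apart by the steps of a 10-fold lower number from compound 1 to compound 3 (1.02 log units; beyond the scatter) and a 28-fold lower number from compound 2 to compound 3 (1.45 log units; beyond the scatter). Compound 4 `Cc1ccc(CNc2ncnc3c2ncn3[C@@H]2O[C@H](CO)[C@@H](O)[C@H]2O)cc1[N+](=O)[O-]` remains to be measured. The change from compound 3 to compound 4 is 4-methyl-3-nitrophenyl in place of 5-methyl-2-nitrophenyl on a saturated chain carbon bound to a nitrogen on an aromatic ring. Within the data shown here, no measured step moves groups around a ring that is otherwise kept; the two large steps into compound 3 only show that the nitro-bearing ring carries the low number, and that ring stays. The step from compound 3 to compound 4 in this assay is therefore expected to stay within the scatter, with direction open, as a 1.4-fold higher number from compound 3 to compound 4 (0.14 log units; within the scatter). Compound 4 is expected at 1800 nM, between 600 nM and 6000 nM.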

Compound 4, half-maximal inhibitory concentration: 1170 nM
Beside the measured number, compound 4's estimate is 1.5-fold (0.19 log units) above it; low and high end bracket the measured number.
By their numbers in this assay, from the lowest: compounds 4 and 3 (each within the scatter of the next); then compound 1; then compound 2.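

Moving the nitro and methyl groups around the ring, with 4-methyl-3-nitrophenyl in place of 5-methyl-2-nitrophenyl, gives no readable difference in this assay (a 1.1-fold lower number from compound 3 to compound 4 (0.04 log units; within the scatter)). On the saturated chain carbon bound to a nitrogen on an aromatic ring, the low number therefore belongs to both arrangements of these two groups, not to one alone. The large gaps from the other two groups also hold for the new arrangement (a 31-fold lower number from compound 2 to compound 4 (1.49 log units; beyond the scatter); a 12-fold lower number from compound 1 to compound 4 (1.06 log units; beyond the scatter)).

Still open, from the compounds shown here alone, is how much of the low number rests on the nitro group and how much on the methyl group, since both are present in compound 3 and compound 4; a plain phenyl ring, or an amine or nitrile in place of the nitro group, would bear on this. Nothing measured here offers an explanation for the result.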